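This account rests on a few compounds, and the source may have more. Where it says the series, first, only, none or still open, it means among the compounds named here.

In a functional assay on MCF7 cells (Homo sapiens) for cytotoxicity, read by sulforhodamine B assay, with a stated time of 48 h (on this read-out lower numbers stand for stronger inhibition and higher numbers for weaker inhibition), compound 1 (`COc1ccc(/C=C/C(=O)c2ccc(N)c(-c3ccc(F)cc3)c2)cc1O`) carries the entry "not determined" (no result reported) and so offers no number, while compound 2 (`COc1ccc(/C=C/C(=O)c2ccc(N)c(-c3ccc(F)cc3)c2)cc1`) reads 7580 nM as the only number shown, with nothing to rank it against. Compound 3 (`Nc1ccc(C(=O)/C=C/c2ccc(O)c(F)c2)cc1-c1ccc(F)cc1`) has 3-fluoro-4-hydroxyphenyl in place of 4-methoxyphenyl on a double-bonded chain carbon bound to a double-bonded chain carbon. Within the data shown here, no measured step is available as a guide, so in this assay only a small move toward stronger inhibition, none beyond the scatter, is expected, the estimated 1.5-fold lower number from compound 2 to compound 3 (0.18 log units; within the scatter) being modest. Compound 3 is estimated at 5000 nM (expected range 1500 nM to 17000 nM) in this measurement.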

Compound 3, half-maximal inhibitory concentration: 18300 nM
Compound 3: middle estimate off by 3.7-fold (0.56 log units), on the low side, and the stated range ends below it.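

In this assay, replacing 4-methoxyphenyl with 3-fluoro-4-hydroxyphenyl on a double-bonded chain carbon bound to a double-bonded chain carbon gives a 2.4-fold higher number from compound 2 to compound 3 (0.38 log units; beyond the scatter) and so weakens inhibition. Among these compounds, this is the first measured sign that the group at this position affects the read-out, and here the change keeps the heavy-atom count while adding a hydrogen-bond donor. No available evidence explains the loss. Whether the fluorine or the hydroxyl accounts for the step remains open, since both enter together. Going by these compounds, how a plain phenyl or a 4-aminophenyl would read at this position also remains open.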